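A few compounds are considered here, and "the series" means these few. Any claim that something is new, unique, unknown or untested is made for them only; others in the source may bear on it.

Compound 1 `Cc1c(-c2ccccc2)cc(-c2ccccc2)n1CCCCCCNC(=O)Oc1ccccc1` and compound 2 `Cc1ccc(-c2ccccc2)n1CCCCCCNC(=O)Oc1ccccc1` share a core; compound 3 `O=C(NCCCCCCn1cc(-c2ccccc2)c2ccccc21)Oc1ccccc1` has a different core, and the difference between the two cores is not broken down here. In an assay on microsomes from brain (strain Sprague-Dawley) for inhibition of Fatty-acid amide hydrolase 1 (Rattus norvegicus), read by fluorescence and HPLC, with stated times of 10 min and 60 min (on this read-out lower numbers stand for stronger inhibition and higher numbers for weaker inhibition), compound 1 gives 460 nM, compound 2 gives 310 nM and compound 3 gives 4900 nM. The change from compound 1 to compound 2 is hydrogen in place of phenyl on an aromatic carbon, and it produced a 1.5-fold lower number from compound 1 to compound 2 (0.17 log units; within the scatter).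

Compound 4 `O=C(NCCCCCCn1ccc2ccccc21)Oc1ccccc1`, not yet measured, differs from compound 3 by hydrogen in place of phenyl on an aromatic carbon. This is the same kind of change as that from compound 1 to compound 2, though the surroundings differ: in compound 1 the place is next to the ring atom that bears a methyl group and two ring bonds from the ring atom that bears a phenyl group, whereas in compound 3 the five-membered ring is part of a fused or bridged system of two rings.

Compound 4 is expected to give 3500 nM in this assay, between 1500 nM and 9000 nM, which means an estimated 1.4-fold lower number from compound 3 to compound 4 (0.15 log units; within the scatter); this rests on compound 3 with 4900 nM and on the small size of a 1.5-fold lower number from compound 1 to compound 2 (0.17 log units; within the scatter).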

Compound 4, half-maximal inhibitory concentration: 250 nM
Estimate against measurement, compound 4: 14-fold (1.15 log units) above; the whole stated range lies above it.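

In this assay, hydrogen in place of phenyl on an aromatic carbon gave a 20-fold lower number from compound 3 to compound 4 (1.29 log units; beyond the scatter), so the phenyl group on the core of compound 3 goes with much weaker inhibition than hydrogen does at that place. The size of this change did not carry from one core to the other: the same change on two cores in this assay, a 1.5-fold lower number (0.17 log units; within the scatter) from compound 1 to compound 2 and a 20-fold lower number (1.29 log units; beyond the scatter) from compound 3 to compound 4, 13-fold (1.12 log units) apart, beyond the scatter of two such steps. This shows that a small step on the core of compound 1 is no safe guide to the same change on the core of compound 3, but it does not show why the two cores differ, and with a single pair on each core it sets no rule for any other core in the series.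

Left open is how a methyl group, an amine or a carboxylic acid at the same place would compare with hydrogen and phenyl on the core of compound 4. Going by these compounds alone, also open is whether a longer chain in place of the one all four compounds share would alter the gap between the two steps.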